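The compounds below may be only part of what the source reports. "The series", "measured", "known", "first", "only" and "open" are said of these compounds alone.

Among the measured compounds shown here, compound 3 `Nc1nn(CC(=O)NCCO)c2nc(-c3ccccc3)cc(C(F)(F)F)c12` gives 96300 nM in a functional assay on DU-145 cells (Homo sapiens) for cytotoxicity, read by MTT assay, with a stated time of 24 h (on this read-out lower numbers stand for stronger inhibition and higher numbers for weaker inhibition), the highest of the three numbers measured so far. Compound 1 `CCNC(=O)Cn1nc(N)c2c(C(F)(F)F)cc(-c3ccccc3)nc21` gives 17900 nM and compound 2 `CCCNC(=O)Cn1nc(N)c2c(C(F)(F)F)cc(-c3ccccc3)nc21` gives 15500 nM in this assay; the step of a 1.2-fold lower number from compound 1 to compound 2 (0.06 log units; within the scatter) stays within the scatter, whereas a 5.4-fold higher number from compound 1 to compound 3 (0.73 log units; beyond the scatter) and a 6.2-fold higher number from compound 2 to compound 3 (0.79 log units; beyond the scatter) both go beyond it. Compound 4 `Nc1nn(CC(=O)NC2CCCCC2)c2nc(-c3ccccc3)cc(C(F)(F)F)c12` has not yet been measured; it differs from compound 3 by cyclohexyl in place of 2-hydroxyethyl on an amide-type nitrogen. The measured steps that bear on this change are a 5.4-fold higher number from compound 1 to compound 3 (0.73 log units; beyond the scatter) and a 6.2-fold higher number from compound 2 to compound 3 (0.79 log units; beyond the scatter), each a modest rise on bringing in the hydroxy; the step from compound 3 to compound 4 takes that hydroxy away again and is therefore expected to run the other way, roughly reversing those steps. For the measured compounds named here, no measured compound carries a ring on the amide-type nitrogen, so that part of the change has no anchor in the numbers and the range is kept wide. Compound 4 is estimated at 14000 nM in this assay, from 5000 nM to 40000 nM, an expected step of a 6.9-fold lower number from compound 3 to compound 4 (0.84 log units; beyond the scatter).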

Compound 4, half-maximal inhibitory concentration: 3100 nM
The estimate for compound 4 lay 4.5-fold (0.65 log units) above the measured number, outside the stated range (below it).
By their numbers in this assay, from the lowest: compound 4; then compounds 2 and 1 (each within the scatter of the next); then compound 3.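

In this assay, the amide-type nitrogen carries cyclohexyl with a lower number than either open chain gives (a 5.8-fold lower number from compound 1 to compound 4 (0.76 log units; beyond the scatter); a 5.0-fold lower number from compound 2 to compound 4 (0.70 log units; beyond the scatter)), whereas ethyl and propyl had stayed within the scatter of each other. Against the hydroxy-bearing chain the step is larger (a 31-fold lower number from compound 3 to compound 4 (1.49 log units; beyond the scatter)), so replacing 2-hydroxyethyl with cyclohexyl does more than undo the rise seen on bringing in the hydroxy. Nothing measured on these compounds accounts for the effect of the ring.

From the compounds shown here alone, whether the lower number follows from the ring itself or from the carbon count stays open, and a hexyl chain or a cyclopentyl on the same nitrogen would help separate the two. A phenyl or a hydroxy-bearing cyclohexyl there would test how far the result holds.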